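This account rests on a few compounds, and the source may have more. Where it says the series, first, only, none or still open, it means among the compounds named here.

Measured so far in a functional assay on K562 cells (Homo sapiens) for antiproliferative activity, read by MTT assay; a higher number here means a weaker inhibitor, a lower number a stronger inhibitor
compound 1 `Cc1ccccc1/C(=N/NC(=S)NCCCCCC(=O)NO)c1ccccc1` gives 3510 nM
compound 2 `Cc1ccc(/C(=N/NC(=S)NCCCCCC(=O)NO)c2ccccc2)cc1` gives 4340 nM

Within the data shown here, compound 2 cannot be separated from compound 1, the only other measured compound, since a 1.2-fold higher number from compound 1 to compound 2 (0.09 log units; within the scatter) stays within the scatter. Next in the series is compound 3 `COc1ccccc1/C(=N/NC(=S)NCCCCCC(=O)NO)c1ccccc1` with 2-methoxyphenyl in place of 4-methylphenyl on a carbon with a double bond to nitrogen and the rest of the structure unchanged. Among the measured compounds shown here, the single measured step bearing on this change is the one between compounds 1 and 2, which only exchanges 2-methylphenyl for 4-methylphenyl. For the measured compounds named here, no measured compound carries 2-methoxyphenyl, so the support is thin. No shift beyond the scatter is expected in this assay and no direction can be argued with confidence. The estimated step is a 1.1-fold lower number from compound 2 to compound 3 (0.06 log units; within the scatter) and remains within the scatter. For compound 3 the estimated value is 3800 nM with an expected range from 1800 nM to 8000 nM.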

Compound 3, half-maximal inhibitory concentration: 3560 nM
For compound 3 the middle estimate is 1.1-fold (0.03 log units) above the measured one, within the range that was stated.
By their numbers in this assay, from the lowest: compounds 1, 3 and 2 (each within the scatter of the next).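

In this assay, among these compounds, the step with methoxy in place of methyl on an aromatic carbon is a 1.0-fold higher number from compound 1 to compound 3 (0.01 log units; within the scatter) and gives the first direct comparison of these two groups in this place. The exchange of 4-methylphenyl for 2-methoxyphenyl on a carbon with a double bond to nitrogen is a 1.2-fold lower number from compound 2 to compound 3 (0.09 log units; within the scatter) and shows that the entering oxygen and hydrogen-bond acceptor do not separate these compounds in this assay. No available evidence bears on these results.

Open, as far as these compounds go, is whether an amine or a carboxylic acid on this aromatic ring would move the number beyond the scatter. Also open, from the compounds shown here alone, is whether 4-methoxyphenyl would differ from 2-methoxyphenyl, and whether a longer chain in the shared core would change the reading.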